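Cyclopentyl in Place of 4-Chlorophenyl: Expected Cytotoxicity

This account rests on a few compounds, and the source may have more. Where it says the series, first, only, none or still open, it means among the compounds named here.

Each value below is a limit of the assay and not a number:
Compound 1 `O=C(c1ccccc1F)N1CCN(c2nc(=O)c3cc(C(F)(F)F)cc([N+](=O)[O-])c3s2)CC1` gives > 125000 nM.
Compound 2 `O=C(c1ccc(Cl)cc1)N1CCN(c2nc(=O)c3cc(C(F)(F)F)cc([N+](=O)[O-])c3s2)CC1` gives > 125000 nM.
Compound 3 `CCC(C)C(=O)N1CCN(c2nc(=O)c3cc(C(F)(F)F)cc([N+](=O)[O-])c3s2)CC1` gives > 125000 nM.

In an ADME assay on Vero cells (Chlorocebus sabaeus) for cytotoxicity, read by MTT assay, with a stated time of 72 h (a lower number here means that less compound is tolerated, a higher number that more compound is tolerated), compound 2 stands at a limit rather than a number, and the same holds for compound 1 and compound 3. Since every value shown is a limit, none of the steps between them can be read: a step that the two limits leave unreadable from compound 1 to compound 2, a step that the two limits leave unreadable from compound 1 to compound 3 and a step that the two limits leave unreadable from compound 2 to compound 3. For the measured compounds named here, the only evidence is the limit of > 125000 nM in this assay, at which 3 of the 3 values shown sit, which says that all three compounds are tolerated up to the highest concentration tested.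

Compound 4 `O=C(C1CCCC1)N1CCN(c2nc(=O)c3cc(C(F)(F)F)cc([N+](=O)[O-])c3s2)CC1` differs from compound 2 in one place: cyclopentyl in place of 4-chlorophenyl on a carbonyl carbon. Going by the values given here, the closest measured step is the one from compound 2 to compound 3, where an aryl group on the carbonyl carbon was also swapped for a branched alkyl group. That step is unreadable; both of its values are limits. On that basis no step beyond the scatter is expected in this assay, and compound 4 is most likely to return a limit as well; the estimated step is a step that the limit leaves unreadable from compound 2 to compound 4. Compound 4 is therefore expected to give about 150000 nM in this assay, within a range of 60000 nM to 400000 nM.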

Compound 4, half-maximal cytotoxic concentration: 120000 nM
Estimate against measurement, compound 4: 1.3-fold (0.10 log units) above, and the stated range covers the measured number.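

In this assay compound 4 gives 120000 nM, the only value among the compounds shown that is a number and not a limit: the limit of > 125000 nM in this assay, at which 3 of the 4 values shown sit.

Set against the other compounds, the change to cyclopentyl reads as an at least 1.0-fold lower number from compound 2 to compound 4 (0.01 log units; that floor lies within the scatter), as an at least 1.0-fold lower number from compound 3 to compound 4 (0.01 log units; that floor lies within the scatter) and as an at least 1.0-fold lower number from compound 1 to compound 4 (0.01 log units; that floor lies within the scatter). These are only floors, since the true size of each step is hidden by the limit at its starting compound, but they show that a non-aromatic carbon ring on this carbonyl carbon can give a readable value in this assay without any step shown to lie beyond the scatter.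

The compounds shown leave open how far the true values of compound 1, compound 2 and compound 3 lie past their shared limit, so the steps among those three cannot be read. They also leave open whether an amine, a carboxylic acid or a longer chain on this carbonyl carbon would give a number clearly lower than that of compound 4.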